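The source may report more compounds than this note shows. Statements on the series, on what has been measured and on what is new or still open speak of the compounds shown alone.

Measured compounds in an assay on HL-60 cells for inhibition of cytochrome P450 26A1 (Homo sapiens), read by HPLC, using microsomes and NADPH, with a stated time of 30 min; on this read-out higher numbers stand for weaker inhibition and lower numbers for stronger inhibition:
- compound 1 `CCCOC(=O)C(Cn1ccnc1)NC(=O)c1c(C)nn(-c2ccccc2)c1Cl` gives 620 nM
- compound 2 `Cc1nn(-c2ccccc2)c(Cl)c1C(=O)NC(Cn1ccnc1)C(=O)OC(C)C` gives 460 nM
- compound 3 `COC(=O)C(Cn1ccnc1)NC(=O)c1nc2ccccc2s1` gives 410 nM

Compound 3 shows the smallest number of the three, yet its gaps to compound 2 and to compound 1 both lie within the scatter, so the three compounds are not separated in this assay. Compound 4 `CC(C)OC(=O)C(Cn1ccnc1)NC(=O)c1nc2ccccc2s1` differs from compound 3 by isopropyl in place of methyl on an oxygen next to a carbonyl group. Within the data shown here, the one measured step at this position, a 1.3-fold lower number from compound 1 to compound 2 (0.13 log units; within the scatter), exchanged one alkyl group for another and stayed within the scatter. Compound 2 and compound 3 differ in more than one place, so only their two values are compared here, and they are close. For compound 4 the expected step is a 1.2-fold lower number from compound 3 to compound 4 (0.07 log units; within the scatter), nothing beyond the scatter. Compound 4 is therefore estimated at 350 nM, with a range of 150 nM to 800 nM.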

Compound 4, half-maximal inhibitory concentration: 630 nM
The estimate for compound 4 lay 1.8-fold (0.26 log units) below the measured number; the range from low to high includes it.
By their numbers in this assay, from the lowest: compounds 3, 2, 1 and 4 (each within the scatter of the next).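

In this assay, isopropyl in place of methyl on an oxygen next to a carbonyl group gives a 1.5-fold higher number from compound 3 to compound 4 (0.19 log units; within the scatter). Isopropyl is now seen on a second core, and this step, like a 1.3-fold lower number from compound 1 to compound 2 (0.13 log units; within the scatter) on the core of compound 1, stays within the scatter, so neither step sets a direction for alkyl changes at this oxygen. No evidence on hand bears on this result.

Still open, as far as these compounds go, is whether a carboxylic acid or a longer chain such as butyl at this position would give a step beyond the scatter.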